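Ethoxy in place of dimethylamino on the shared core

The compounds below may be only part of what the source reports. "The series", "measured", "known", "first", "only" and "open" are said of these compounds alone.

Values in a functional assay on Caco-2 cells (Homo sapiens) for antiproliferative activity, with a stated time of 48 h; a lower number here means a stronger inhibitor, a higher number a weaker inhibitor:
- compound 1 `CCOC(=O)c1ccc(-c2ccc(N(CC)CC)nn2)cc1`: 4000 nM
- compound 2 `CCOC(=O)c1ccc(-c2ccc(N(C)C)nn2)cc1`: > 25000 nM
- compound 3 `COC(=O)c1ccc(-c2ccc(N(C)C)nn2)cc1`: > 25000 nM

Compound 2 gives > 25000 nM, which is a limit of this assay and not a number. For compound 2 this is the limit of > 25000 nM in this assay, at which 2 of the 3 values shown sit. Compound 3 gives > 25000 nM, which is a limit as well. Compound 4 `CCOC(=O)c1ccc(-c2ccc(OCC)nn2)cc1` carries ethoxy in place of dimethylamino on an aromatic carbon, para to a large group (ethoxy in place of dimethylamino on an aromatic carbon).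

The measured step closest to this change is the one between the two amino groups, an at least 6.2-fold higher number from compound 1 to compound 2 (0.79 log units; beyond the scatter). It shows that a change on this carbon can matter, but ethoxy itself has not been measured on this core. The other step, a step that the two limits leave unreadable from compound 2 to compound 3, gives no size to carry over. A modest move towards a lower number is therefore expected, and compound 4 may well stay at the limit. The expected step is an at least 1.6-fold lower number from compound 2 to compound 4 (0.22 log units; that floor lies within the scatter). The estimate for compound 4 is 15000 nM, with an expected range of 5000 nM to 40000 nM.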

Compound 4, half-maximal inhibitory concentration: > 25000 nM
Compound 4 gave a limit, no number; the forecaster's own chance of this, stated with the estimate: 45%; at least 1.6-fold (0.22 log units) between middle value and limit.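

In this assay compound 4 gives > 25000 nM, which is a limit of the assay and not a number. On this aromatic carbon, ethoxy in place of diethylamino gives an at least 6.2-fold higher number from compound 1 to compound 4 (0.79 log units; beyond the scatter), so a swap to a group without the amine nitrogen also leaves the series at the limit, as dimethylamino did. Compound 1 thus remains the only compound shown with a number, and the steps among the compounds at the limit cannot be read: the limit of > 25000 nM in this assay, at which 3 of the 4 values shown sit.

Open, on these data alone, is whether the number for compound 1 follows the amine nitrogen, the length of its chains on this carbon, or both. A propoxy group or a dipropylamino group at this position would bear on that question.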